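This account rests on a few compounds, and the source may have more. Where it says the series, first, only, none or still open, it means among the compounds named here.

Measured compounds in a functional assay on HEK293 cells for agonist activity at Free fatty acid receptor 1 (Homo sapiens), read by fluorescence and calcium flux, with a stated time of 10 min; on this read-out lower numbers stand for an effect already at smaller amounts and higher numbers for an effect only at larger amounts of compound:

Compound 1 `COc1ccc2c(c1)OC(COc1ccc(CCC(=O)O)c(F)c1)CC2` gives 2110 nM.
Compound 2 `CC#C[C@@H](CC(=O)O)c1ccc(OC[C@H]2COc3ccc(Cl)cc3O2)cc1` gives 50 nM.
Compound 3 `CC#C[C@@H](CC(=O)O)c1ccc(OC[C@H]2COc3cc(F)c(Cl)cc3O2)cc1` gives 210 nM.

Compound 3 stands second highest of the three numbers in this assay. Its nearest neighbour is compound 2, and the only single-point step shown is a 4.2-fold higher number from compound 2 to compound 3 (0.62 log units; beyond the scatter). Compound 1, built on a different core, lies furthest from compound 3.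

Compound 4 `CC#C[C@@H](CC(=O)O)c1ccc(OC[C@H]2COc3cc(Br)c(Cl)cc3O2)cc1` arises from compound 3 by bromo in place of fluoro on an aromatic carbon. Going by the values given here, no measured pair shows a bromo in place of a fluoro, so the only step that bears on this position is a 4.2-fold higher number from compound 2 to compound 3 (0.62 log units; beyond the scatter), which shows that placing a group on this carbon moved the number beyond the scatter. Whether a bromo there behaves like a fluoro or like a hydrogen cannot be read from these three compounds. The expected step is therefore a 1.4-fold higher number from compound 3 to compound 4 (0.15 log units; within the scatter), set close to no change with a wide range. Compound 4 is expected to give about 300 nM in this assay, between 80 nM and 1200 nM.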

Compound 4, half-maximal effective concentration: 200 nM
Beside the measured number, compound 4's estimate is 1.5-fold (0.18 log units) above it, and the stated range covers the measured number.
By their numbers in this assay, from the lowest: compound 2; then compounds 4 and 3 (each within the scatter of the next); then compound 1.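

In this assay the exchange of fluoro for bromo on this aromatic carbon, ortho to the chloro group, gives a 1.1-fold lower number from compound 3 to compound 4 (0.02 log units; within the scatter) and so does not separate the two halogens. The step of a 4.0-fold higher number from compound 2 to compound 4 (0.60 log units; beyond the scatter) shows that a bromo, like the fluoro before it, stands with a higher number than hydrogen at this carbon, so among these compounds the shift no longer rests on fluoro alone. Nothing measured here accounts for this result.

The compounds shown leave open whether a methoxy group, a nitrile or an amine on this carbon would give a similar number to the two halogens. From the compounds shown here alone, all of them also carry the chloro group, so how the step would look with a hydrogen or a methyl in its place remains unknown.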